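The source may hold more compounds than are shown below. What is called first, only, known or untested is meant among the compounds shown, and "the series" means these compounds.

Compound 1 `CC(C)(C)NC(=O)NCCS(=O)(=O)NC(=O)c1ccc(Nc2nc(NC3(c4ccc(Cl)cc4)CC3)nc(OCC(F)(F)F)n2)cc1` gives 49 nm/s
Compound 2 `CCS(=O)(=O)NC(=O)c1ccc(Nc2nc(NC3(c4ccc(Cl)cc4)CC3)nc(OCC(F)(F)F)n2)cc1` gives 28 nm/s
Compound 3 `O=C(NS(=O)(=O)c1ccccc1)c1ccc(Nc2nc(NC3(c4ccc(Cl)cc4)CC3)nc(OCC(F)(F)F)n2)cc1` gives 182 nm/s

In a physicochemical assay for permeability, using PAMPA, at pH 7.4 (a higher number here means that the compound crosses the layer faster, a lower number that the compound crosses the layer more slowly), compound 3 stands highest of the three numbers; the step of a 6.5-fold higher number from compound 2 to compound 3 (0.81 log units; beyond the scatter) and the step of a 3.7-fold higher number from compound 1 to compound 3 (0.57 log units; beyond the scatter) both lie beyond the scatter. Compound 4 `CC(=O)NCCS(=O)(=O)NC(=O)c1ccc(Nc2nc(NC3(c4ccc(Cl)cc4)CC3)nc(OCC(F)(F)F)n2)cc1` has not yet been measured in this assay. It differs from compound 3 by 2-acetamidoethyl in place of phenyl on a sulfonyl sulfur. For the measured compounds named here, both measured steps toward compound 3 bear on this change: each replaces a group on the same sulfonyl sulfur with phenyl, and compound 4 undoes that, returning to a chain resembling the one in compound 1 but shorter. A drop beyond the scatter is therefore expected, of about a 4.6-fold lower number from compound 3 to compound 4 (0.66 log units; beyond the scatter), landing near the numbers of compound 1 and compound 2. Compound 4 is estimated at 40 nm/s, with a range from 15 nm/s to 100 nm/s.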

Compound 4, apparent permeability: 7 nm/s
Estimate against measurement, compound 4: 5.7-fold (0.76 log units) above; measured number outside the range, below it.
By their numbers in this assay, from the lowest: compound 4; then compounds 2 and 1 (each within the scatter of the next); then compound 3.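

In this assay the step of a 26-fold lower number from compound 3 to compound 4 (1.41 log units; beyond the scatter) is the largest seen on this sulfonyl sulfur, and compound 4 lies lowest of the four. The chain's substituent also counts: acetamido gives a 4.0-fold lower number from compound 2 to compound 4 (0.60 log units; beyond the scatter), whereas the ((tert-butyl)carbamoyl)amino group of compound 1 stayed within the scatter of compound 2. The chain's end alone gives a 7.0-fold lower number from compound 1 to compound 4 (0.85 log units; beyond the scatter), with methyl replacing (tert-butyl)amino on the carbonyl carbon.

No measurement shown explains these steps. From the compounds shown here alone, whether an amine or a longer chain on this sulfonyl sulfur would sit nearer compound 4 or compound 1 remains open.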